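Methylating the Ring Nitrogen of Compound 1

The source may hold more compounds than are shown below. What is called first, only, known or untested is meant among the compounds shown, and "the series" means these compounds.

Compound 1 `Cc1[nH]nc(N)c1-c1ccc(Cl)c(Cl)c1` is measured in an assay on Sf9 cells for inhibition of inhibitor of nuclear factor kappa-B kinase subunit epsilon (Homo sapiens), read by ADP-Glo, with a stated time of 60 min (a lower number here means a stronger inhibitor, a higher number a weaker inhibitor), only as a limit, > 100000 nM, not as a number. Compound 3 `Cc1c(N)n[nH]c1-c1ccc(Cl)c(Cl)c1` likewise returns a limit, > 100000 nM. Compound 2 `Cc1[nH]nc(N)c1-c1cccc(Cl)c1` gives a number in this assay, 93400 nM. Within the data shown here, the single measured step, an at least 1.0-fold lower number from compound 1 to compound 2 (0.02 log units; that floor lies within the scatter), starts from a limit and so fixes only a floor that lies within the scatter, as the limit at which two of the three values sit shows (the limit of > 100000 nM in this assay, at which 2 of the 3 values shown sit).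

Compound 4 `Cc1c(-c2ccc(Cl)c(Cl)c2)c(N)nn1C` differs from compound 1 by methyl in place of hydrogen on an aromatic nitrogen. Among the measured compounds shown here, no measured step touches that aromatic nitrogen, so nothing in the data speaks to the size or direction of the change. Compound 1 stands at a limit with no number to move from. The step that the limit leaves unreadable from compound 1 to compound 4 is therefore expected to be none beyond the scatter, leaving compound 4 at or near the same limit in this assay. Compound 4 is estimated at 150000 nM, with a range from 50000 nM to 500000 nM, and a limit rather than a number is the likelier report.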

Compound 4, half-maximal inhibitory concentration: > 100000 nM
Compound 4 was reported as a limit; the forecaster's own chance of this, stated with the estimate: 80%; the middle value is on the limit's open side.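

Compound 1 and compound 4 both stand only as limits in this assay and no step can be read between them: the limit of > 100000 nM in this assay, at which 3 of the 4 values shown sit.

The compounds shown leave open what methyl in place of hydrogen on an aromatic nitrogen does to inhibition, with no number on either side of that change.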